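Hydroxymethyl on the propargyl thioether of compound 1

The compounds below may be only part of what the source reports. "The series", "measured", "known", "first", "only" and "open" are said of these compounds alone.

Measured compounds:
- compound 1, `C#CCSc1cnc2ccccc2c1[Se]CC#CCCl`: 3.2 ug/mL
- compound 2, `CSc1cnc2ccccc2c1[Se]CC#CCO`: 3.4 ug/mL
- compound 3, `CSc1cnc2ccccc2c1SCC#CCOC(=O)/C=C/c1ccccc1`: 66.6 ug/mL

Of the compounds shown here, three sharing one core have been tested in a functional assay on SW707 cells (Homo sapiens) for antiproliferative activity, with a stated time of 72 h; on this read-out lower numbers stand for stronger inhibition and higher numbers for weaker inhibition. Compound 1 gives the lowest of the three numbers, but compound 2 sits within the usual scatter of it, so the two cannot be told apart on this read-out. Compound 3 stands well beyond the scatter, with a markedly higher number than either.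

The step of interest leads from compound 1 to compound 4, `OCC#CCSc1cnc2ccccc2c1[Se]CC#CCCl`. The difference is hydroxymethyl in place of hydrogen on a triple-bonded carbon. The change sits on the propargyl chain attached to sulfur, while the chain on selenium is left as it is.

Going by the values given here, no pair among the measured compounds differs in a single place, so there is no directly comparable step. Compound 2 carries a hydroxy group on a different chain and gives a number close to that of compound 1, which offers the only hint available. On that basis compound 4 is expected to show a step of a 1.1-fold higher number from compound 1 to compound 4 (0.04 log units; within the scatter), that is, no change beyond the scatter in either direction. The estimate for compound 4 is 3.5 ug/mL, with a range from 1.5 ug/mL to 8 ug/mL.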

Compound 4, concentration for 50% inhibition: 3.3 ug/mL
For compound 4 the middle estimate is 1.1-fold (0.03 log units) above the measured one; measured number inside the range.
By their numbers in this assay, from the lowest: compounds 1, 4 and 2 (each within the scatter of the next); then compound 3.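

In this assay, hydroxymethyl in place of hydrogen on a triple-bonded carbon gives a 1.0-fold higher number from compound 1 to compound 4 (0.01 log units; within the scatter), which lies within the scatter, so the two compounds cannot be told apart on this read-out. Going by these compounds alone, this is the first step that differs in one place only, and it shows that this position accepts the larger group, with its hydrogen-bond donor and acceptor, without a difference that can be read: ethynyl becomes 3-hydroxyprop-1-yn-1-yl, and the number in this assay does not separate the pair. Nothing in the available data bears on why the step comes out this way.

Going by these compounds, whether an amine, a carboxylic acid or a longer chain on the same triple-bonded carbon would also fall within the scatter remains open, since a single substituent at one position sets no trend. Also open, on these data alone, is whether hydroxymethyl would give a similar step if the chlorine-bearing chain on selenium were replaced by a chain ending in a hydroxy group.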